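The source may hold more compounds than are shown below. What is called first, only, known or untested is meant among the compounds shown, and "the series" means these compounds.

Among the compounds with values here, compound 3 `COc1ccc(C(=O)O)cc1OCCCCOc1ccc(C(=O)CC2CCCC2)c(O)c1C` gives 425 nM in an assay on HEK293 cells for positive allosteric modulation of metabotropic glutamate receptor 2 (Rattus norvegicus), read by thallium flux, with a stated time of 2.5 min (on this read-out higher numbers stand for an effect only at larger amounts of compound and lower numbers for an effect already at smaller amounts), and stands highest of the three numbers so far: compound 1 `CCC(=O)c1ccc(OCCCCOc2cc(C(=O)O)ccc2OC)c(C)c1O` gives 162 nM and compound 2 `CCCC(=O)c1ccc(OCCCCOc2cc(C(=O)O)ccc2OC)c(C)c1O` gives 103 nM. Compound 4 `COc1ccc(C(=O)O)cc1OCCCCOc1ccc(C(C)=O)c(O)c1C` differs from compound 3 by hydrogen in place of cyclopentyl on a saturated chain carbon bound to a carbonyl carbon. Within the data shown here, two measured steps bear on this change: a 2.6-fold higher number from compound 1 to compound 3 (0.42 log units; beyond the scatter) and a 4.1-fold higher number from compound 2 to compound 3 (0.62 log units; beyond the scatter), both beyond the scatter and in the same direction. The step of a 1.6-fold lower number from compound 1 to compound 2 (0.20 log units; within the scatter) shows that a smaller change on this chain stays within the scatter. In compound 4 the loss of the cyclopentyl is expected to undo that rise, with the step estimated at a 2.1-fold lower number from compound 3 to compound 4 (0.33 log units; beyond the scatter). For compound 4 the expected value is 200 nM, with a range of 90 nM to 450 nM.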

Compound 4, half-maximal effective concentration: 1090 nM
For compound 4 the middle estimate is 5.5-fold (0.74 log units) below the measured one; measured number outside the range, above it.
By their numbers in this assay, from the lowest: compounds 2 and 1 (each within the scatter of the next); then compound 3; then compound 4.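

On the saturated chain carbon bound to a carbonyl carbon in this assay, hydrogen gives the highest number of the four compounds, with a 2.6-fold higher number from compound 3 to compound 4 (0.41 log units; beyond the scatter), a 6.7-fold higher number from compound 1 to compound 4 (0.83 log units; beyond the scatter) and an 11-fold higher number from compound 2 to compound 4 (1.02 log units; beyond the scatter). Cyclopentyl therefore stands above methyl and ethyl yet still below hydrogen, so each of the three groups gives a lower number than the bare acetyl compound. Nothing measured accounts for this.

As far as these compounds go, whether a straight chain longer than ethyl, a phenyl or an amine on this carbon also keeps the number low remains open. Methyl and ethyl stay unresolved from each other, lying within the scatter.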